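The source may report more compounds than this note shows. Statements on the series, on what has been measured and on what is new or still open speak of the compounds shown alone.

Measured in a physicochemical assay for solubility, using the shake flask method, with a stated time of 12 h; on this read-out higher numbers stand for higher solubility and lower numbers for lower solubility:
- Compound 1 `O=C(/C=C/c1ccc(O)c(O)c1)CC(=O)/C=C/c1cc(O)ccc1O`: 54000 nM
- Compound 2 `O=C(/C=C/c1cc(O)ccc1O)CC(=O)/C=C/c1cccc(O)c1O`: 100000 nM
- Compound 3 `O=C(/C=C/c1ccccc1O)CC(=O)/C=C/c1cc(O)ccc1O`: 4400 nM

Compound 3 has the lowest number of the three. Compound 4 `O=C(/C=C/c1cc(O)ccc1O)CC(=O)/C=C/c1cc(O)ccc1O` differs from it by one change: hydroxy in place of hydrogen on an aromatic carbon. This is hydroxy in place of hydrogen on an aromatic carbon, giving 2,5-dihydroxyphenyl instead of 2-hydroxyphenyl.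

The closest measured step is a 23-fold lower number from compound 2 to compound 3 (1.36 log units; beyond the scatter). It is the reverse kind of change, hydrogen in place of hydroxy, though at another place on the ring. Also relevant is a 12-fold lower number from compound 1 to compound 3 (1.09 log units; beyond the scatter). Both are large, so a large rise in this assay is expected, read in the opposite direction. The expected step is an 11-fold higher number from compound 3 to compound 4 (1.06 log units; beyond the scatter). The estimated value for compound 4 is 50000 nM, with an expected range from 15000 nM to 150000 nM.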

Compound 4, solubility: 5000 nM
The estimate for compound 4 lay 10-fold (1.00 log units) above the measured number, outside the stated range (below it).
By their numbers in this assay, from the lowest: compounds 3 and 4 (each within the scatter of the next); then compounds 1 and 2 (each within the scatter of the next).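

In this assay, hydroxy in place of hydrogen para to a hydroxy group gives a 1.1-fold higher number from compound 3 to compound 4 (0.06 log units; within the scatter), so a second hydroxy on this ring does not by itself bring the higher numbers. Where that hydroxy sits does count: 2,5-dihydroxyphenyl in place of 2,3-dihydroxyphenyl gives a 20-fold lower number from compound 2 to compound 4 (1.30 log units; beyond the scatter), and in place of 3,4-dihydroxyphenyl it gives an 11-fold lower number from compound 1 to compound 4 (1.03 log units; beyond the scatter). Nothing available explains this difference.

Open, as far as these compounds go, is how an amine or a carboxylic acid at this same carbon would compare with hydroxy. Also open, from the compounds shown here alone, is whether these ring patterns would rank the same on a different second ring.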